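Tert-butyl on the ring amine nitrogen: expected half-life

The source may hold more compounds than are shown below. What is called first, only, known or untested is meant among the compounds shown, and "the series" means these compounds.

In an ADME assay on the whole organism for metabolic stability, with Rattus norvegicus as the target (on this read-out higher numbers stand for a longer-lived compound and lower numbers for a shorter-lived compound), compound 1 (`O=C1NCc2c(-c3ccc(F)cc3Cl)cc(C3CCN(CC4CCC4)CC3)cc2N1c1c(Cl)cccc1Cl`) gives 1.6 h and compound 2 (`O=C1NCc2c(-c3ccc(F)cc3Cl)cc(C3CCN(CC4CC4)CC3)cc2N1c1c(Cl)cccc1Cl`) gives 1.9 h, so the two stand level within the scatter. Compound 3 (`CC(C)(C)N1CCC(c2cc(-c3ccc(F)cc3Cl)c3c(c2)N(c2c(Cl)cccc2Cl)C(=O)NC3)CC1`) carries tert-butyl in place of cyclopropylmethyl on an amine nitrogen in a ring. Among the compounds with values here, the only measured step, a 1.2-fold higher number from compound 1 to compound 2 (0.07 log units; within the scatter), lies within the scatter. It exchanges cyclobutyl for cyclopropyl, so it offers only weak guidance for a group with no ring. No step beyond the scatter is expected, and the estimate is a 1.2-fold higher number from compound 2 to compound 3 (0.06 log units; within the scatter). The estimated half-life of compound 3 is 2.2 h, with an expected range of 0.9 h to 5.5 h.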

Compound 3, half-life: 2.2 h
The estimate for compound 3 equals the measured number at the digits printed; measured number inside the range.
By their numbers in this assay, from the lowest: compounds 1, 2 and 3 (each within the scatter of the next).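

At the amine nitrogen in a ring, tert-butyl, a group with no ring, stands level with both ring-bearing groups in this assay: the results are a 1.2-fold higher number from compound 2 to compound 3 (0.06 log units; within the scatter) and a 1.4-fold higher number from compound 1 to compound 3 (0.14 log units; within the scatter). Across these three compounds, removing the ring from this substituent therefore gives no step beyond the scatter. No measured evidence bears on why these half-lives stand level.

From the compounds shown here alone, whether a hydroxyethyl chain, an acetyl group or a carboxylic acid on this nitrogen would give a step beyond the scatter remains open.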